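This account rests on a few compounds, and the source may have more. Where it says the series, first, only, none or still open, it means among the compounds named here.

Working notes on the series.

Compound 1 `CCCCNc1nc(SCC)nc2ncccc12` is the reference point. In a functional assay on T-24 cells (Homo sapiens) for cytotoxicity, read by neutral red uptake, with a stated time of 72 h (on this read-out higher numbers stand for weaker inhibition and lower numbers for stronger inhibition), compound 1 gives 20900 nM, the highest number of the three measured compounds. Compound 2 `CCCCCCNc1nc(SCC)nc2ncccc12` gives 5900 nM in this assay, and compound 3 `CCCCCCCNc1nc(SCC)nc2ncccc12` gives 5300 nM. Lengthening the chain on the amine nitrogen brings a 3.5-fold lower number from compound 1 to compound 2 (0.55 log units; beyond the scatter) and a 3.9-fold lower number from compound 1 to compound 3 (0.60 log units; beyond the scatter), whereas between the two longer chains there is only a 1.1-fold lower number from compound 2 to compound 3 (0.05 log units; within the scatter).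

Compound 4 `CCCCNc1nc(SC(C)C)nc2ncccc12` differs from compound 1 by methyl in place of hydrogen on a saturated chain carbon bound to a saturated chain carbon and a sulfur. Going by the values given here, every measured step changes the chain on the amine nitrogen; none touches the sulfur-bound chain, so no measured step bears directly on this change. Among the compounds with values here, the butylamino chain of compound 1 is kept in compound 4, and the only guide is the value of compound 1 itself. The expected step is a 1.0-fold lower number from compound 1 to compound 4 (0.02 log units; within the scatter), within the scatter. Compound 4 is therefore estimated at 20000 nM, with a range from 8000 nM to 50000 nM in this assay.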

Compound 4, half-maximal inhibitory concentration: 12300 nM
Estimate against measurement, compound 4: 1.6-fold (0.21 log units) above; the measured number falls inside the stated range.
By their numbers in this assay, from the lowest: compounds 3 and 2 (each within the scatter of the next); then compounds 4 and 1 (each within the scatter of the next).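

In this assay, the first change shown on the sulfur-bound chain, ethylsulfanyl to isopropylsulfanyl, gives a 1.7-fold lower number from compound 1 to compound 4 (0.23 log units; within the scatter), so one added methyl at this position leaves the number within the scatter when the butylamino chain is kept. Methyl in place of hydrogen likewise stays within the scatter further out on the amine chain, and the two steps cannot be told apart: the same change on two cores in this assay, a 1.1-fold lower number (0.05 log units; within the scatter) from compound 2 to compound 3 and a 1.7-fold lower number (0.23 log units; within the scatter) from compound 1 to compound 4, 1.5-fold (0.18 log units) apart, within the scatter of two such steps. Among the compounds shown, a step beyond the scatter still comes only from the amine chain, as in a 3.5-fold lower number from compound 1 to compound 2 (0.55 log units; beyond the scatter).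

On these data alone, whether isopropylsulfanyl behaves the same way on the longer amine chain of compound 2 remains open. Also open, as far as these compounds go, is whether a larger sulfur-bound group, such as tert-butyl or benzyl, or a chain ending in a carboxylic acid, would give a step beyond the scatter.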